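This account rests on a few compounds, and the source may have more. Where it says the series, first, only, none or still open, it means among the compounds named here.

Three compounds sharing one core have been measured in an ADME assay on THP-1 cells (Homo sapiens) for cytotoxicity, read by MTT assay, with a stated time of 72 h; a higher number here means that more compound is needed for the effect, a lower number that less compound is needed:

compound 1 `Cc1ccc(-c2ccc3[nH]c(=O)nc(-c4ccccc4)c3c2)cn1`: > 50000 nM, a limit
compound 2 `O=c1nc(-c2ccccc2)c2cc(-c3ccccc3F)ccc2[nH]1`: 50000 nM
compound 3 `O=c1nc(-c2ccccc2)c2cc(-c3cncnc3)ccc2[nH]1`: > 50000 nM, a limit

Compound 3 has no number in this assay, only a limit: > 50000 nM. The series as a whole stands at the limit of > 50000 nM in this assay, at which 2 of the 3 values shown sit.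

The step to compound 4 `Cn1nccc1-c1ccc2[nH]c(=O)nc(-c3ccccc3)c2c1` is 1-methyl-1H-pyrazol-5-yl in place of pyrimidin-5-yl on an aromatic carbon, so a five-membered aromatic ring replaces a six-membered one. For the measured compounds named here, none of the measured compounds carries a five-membered ring in that place.

Three exchanges of the same kind bear on this change: a number no higher from compound 1 to compound 2 (the limit leaves the size open), a number no lower from compound 2 to compound 3 (the limit leaves the size open) and a step that the two limits leave unreadable from compound 1 to compound 3. None of them has a readable size, and none shows that any of these groups moves the read-out. No step beyond the scatter is therefore expected in this assay, and no direction can be favoured. The expected step is a number no higher from compound 3 to compound 4 (the limit leaves the size open). Going by the values given here, this expectation leans on compound 2, the only one with a number, at 50000 nM. Another limit is the most likely report for the new compound. The estimate for compound 4 is 50000 nM, with an expected range of 20000 nM to 100000 nM.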

Compound 4, half-maximal effective concentration: > 50000 nM
Compound 4 gave a limit, no number; the forecaster's own chance of this, stated with the estimate: 70%; the middle value lies on the limit itself.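

In this assay compound 4 gives > 50000 nM, which is a limit and not a number. A five-membered aromatic ring, 1-methyl-1H-pyrazol-5-yl, on this aromatic carbon therefore ends in the same kind of report as the six-membered pyrimidin-5-yl of compound 3, so this change of ring size yields no readable shift. For the compounds shown here, the steps from compound 1 and compound 3 cannot be read, and the only one with a direction is a number no lower from compound 2 to compound 4 (the limit leaves the size open); compound 2 remains the only compound with a number, and the series now stands as follows: the limit of > 50000 nM in this assay, at which 3 of the 4 values shown sit.

The compounds shown leave open whether any group on this aromatic carbon can bring the read-out in this assay clearly under the limit, since all four carry a single aromatic ring there and none carries a primary amine or a carboxylic acid. They also leave open whether the phenyl on the shared core plays any part, as it is the same in all four compounds.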